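The compounds below may be only part of what the source reports. "The series", "measured", "known", "first", "only" and "open" are said of these compounds alone.

Measured in a functional assay on HT-29 cells (Homo sapiens) for antiproliferative activity, read by sulforhodamine B assay, with a stated time of 72 h; a higher number here means a weaker inhibitor, a lower number a stronger inhibitor:
- compound 1 `CN(C)C(=S)N/N=C/c1ccc2ccccc2n1`: 20 nM
- compound 2 `NC(=S)N/N=C/c1nc2ccccc2s1`: > 100000 nM
- compound 3 `NC(=S)N/N=C/c1ccc2ccccc2n1`: 100000 nM

The entry for compound 2 is a limit of the assay, not a number. Of the two true numbers, the higher belongs to compound 3, at 100000 nM, which makes it a weak inhibitor in this assay.

Compound 4 `Fc1ccc(NC(=S)N/N=C/c2ccc3ccccc3n2)cc1` carries 4-fluorophenyl in place of hydrogen on an amide-type nitrogen. Going by the values given here, one measured step bears on this change. Amino in place of dimethylamino on a thiocarbonyl carbon gave a 5000-fold higher number from compound 1 to compound 3 (3.70 log units; beyond the scatter), which is large and beyond the scatter. Substitution on this nitrogen can therefore matter greatly, and the loss of substituents raised the number. Among the compounds with values here, no measured compound carries 4-fluorophenyl, so the size of the step is uncertain. A sizeable step towards a lower number is nevertheless expected, probably smaller than the measured one.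

The expected change is a 33-fold lower number from compound 3 to compound 4 (1.52 log units; beyond the scatter). For compound 4 the estimated value is 3000 nM, with an expected range from 200 nM to 50000 nM.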

Compound 4, half-maximal inhibitory concentration: 28500 nM
The estimate for compound 4 lay 9.5-fold (0.98 log units) below the measured number, within the range that was stated.
By their numbers in this assay, from the lowest: compound 1; then compound 4; then compound 3.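

In this assay, 4-fluorophenyl in place of hydrogen on the amide-type nitrogen gave a 3.5-fold lower number from compound 3 to compound 4 (0.55 log units; beyond the scatter), so this substitution does lower the number, but only modestly. Set against a 5000-fold higher number from compound 1 to compound 3 (3.70 log units; beyond the scatter), this shows that the size of the effect at this nitrogen depends strongly on what is placed there: a substituent on it does not in itself bring back the full difference seen with dimethylamino. Compound 2 is recorded at a limit of the assay rather than a number and enters no step here: the limit of > 100000 nM in this assay, at which 1 of the 4 values shown sits.

From the compounds shown here alone, it remains open whether the modest gain belongs to the phenyl ring or to its fluorine. Going by these compounds, it also remains open whether a single methyl group or a morpholine ring on this nitrogen would behave more like dimethylamino or more like 4-fluorophenyl.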